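The compounds below may be only part of what the source reports. "The series", "measured", "known", "first", "only" and "open" are said of these compounds alone.

The measured compounds:
Compound 1 `COc1cc2c(Oc3ccc(NC(=O)c4nn(-c5cccc(F)c5)c(=O)c5ccccc45)cc3F)ccnc2cc1OCCCN1CCCC1`: 880 nM
Compound 2 `COc1ccc(-n2nc(C(=O)Nc3ccc(Oc4ccnc5cc(OCCCN6CCCC6)c(OC)cc45)c(F)c3)c3ccccc3c2=O)cc1`: 3450 nM

In a functional assay on MDA-MB-231 cells (Homo sapiens) for cytotoxicity, read by MTT assay, with a stated time of 72 h (on this read-out lower numbers stand for stronger inhibition and higher numbers for weaker inhibition), compound 2 gives 3450 nM, the highest of the two numbers shown. Its nearest neighbour is compound 1, which in this assay gives 880 nM. Among the measured compounds shown here, the single measured step, a 3.9-fold higher number from compound 1 to compound 2 (0.59 log units; beyond the scatter), concerns the group on an aromatic nitrogen, far from the chain end.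

Compound 3 `COc1ccc(-n2nc(C(=O)Nc3ccc(Oc4ccnc5cc(OCCCN6CCCCC6)c(OC)cc45)c(F)c3)c3ccccc3c2=O)cc1` is the next compound and carries one change relative to compound 2: piperidin-1-yl in place of pyrrolidin-1-yl on a saturated chain carbon, three bonds along the chain from an oxygen on an aromatic ring. For the measured compounds named here, no measured step touches this part of the molecule, so there is nothing among the numbers that points up or down for this change. The expectation is therefore a step that stays within the scatter. Compound 3 is expected to give about 3400 nM, with a likely range from 1500 nM to 7500 nM. This corresponds to an estimated step of a 1.0-fold lower number from compound 2 to compound 3 (0.01 log units; within the scatter).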

Compound 3, half-maximal inhibitory concentration: 2010 nM
Compound 3: the middle estimate sits 1.7-fold (0.23 log units) above what was measured; the range from low to high includes it.
By their numbers in this assay, from the lowest: compound 1; then compounds 3 and 2 (each within the scatter of the next).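

Among the compounds shown here, this is the first measured change at this place, on a saturated chain carbon, three bonds along the chain from an oxygen on an aromatic ring. In this assay, piperidin-1-yl in place of pyrrolidin-1-yl gives a 1.7-fold lower number from compound 2 to compound 3 (0.23 log units; within the scatter), so with 4-methoxyphenyl on the aromatic nitrogen, this read-out does not separate the five-membered ring from the six-membered ring. No measurement is available here that would explain this result.

From the compounds shown here alone, it remains open whether the same swap would give a similar step with 3-fluorophenyl on the aromatic nitrogen, the group carried by compound 1. The compounds shown also leave open how a morpholine ring or a dimethylamino group in this place, or a longer chain leading to the piperidin-1-yl ring, would read in this assay.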